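A few compounds are considered here, and "the series" means these few. Any claim that something is new, unique, unknown or untested is made for them only; others in the source may bear on it.

In a functional assay (aorta) with Oryctolagus cuniculus as the target (a higher number here means a weaker inhibitor, a lower number a stronger inhibitor), three compounds on the shared core have been measured. Compound 1 (`CC1=C(C)C(=O)C(C(CCCCCC(=O)O)c2ccc(F)cc2)=C(C)C1=O`), the fluoro member, gives 48 nM. Compound 2 (`CC1=C(C)C(=O)C(C(CCCCCC(=O)O)c2ccc(Cl)cc2)=C(C)C1=O`), the chloro member, gives 280 nM. Compound 3 (`COc1ccc(C(CCCCCC(=O)O)C2=C(C)C(=O)C(C)=C(C)C2=O)cc1`), the methoxy member, gives 3000 nM, the highest number of the three.

Compound 4 (`CC1=C(C)C(=O)C(C(CCCCCC(=O)O)c2cccs2)=C(C)C1=O`) carries thiophen-2-yl in place of 4-methoxyphenyl on a saturated chain carbon bound to a double-bonded ring carbon and a saturated chain carbon.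

Within the data shown here, no measured step makes this exchange, so the evidence is indirect. Among the halogen members, the data show a 5.8-fold higher number from compound 1 to compound 2 (0.77 log units; beyond the scatter). The two steps ending at the methoxy member are larger: an 11-fold higher number from compound 2 to compound 3 (1.03 log units; beyond the scatter) and a 63-fold higher number from compound 1 to compound 3 (1.80 log units; beyond the scatter). Going by these compounds, compound 4 has no methoxy group, so it is expected to fall back towards compound 1 and compound 2, though the thiophen-2-yl group itself is untested here.

The expected change is large, a 25-fold lower number from compound 3 to compound 4 (1.40 log units; beyond the scatter). For compound 4 the estimated value is 120 nM, with an expected range of 30 nM to 500 nM.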

Compound 4, half-maximal inhibitory concentration: 760 nM
Compound 4: middle estimate off by 6.3-fold (0.80 log units), on the low side; measured number outside the range, above it.
By their numbers in this assay, from the lowest: compound 1; then compound 2; then compound 4; then compound 3.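

Working notes on the aryl group at the saturated chain carbon: in this assay the ring itself can be exchanged at this position, not just the substituent on the phenyl ring, and thiophen-2-yl in place of 4-methoxyphenyl gives a 3.9-fold lower number from compound 3 to compound 4 (0.60 log units; beyond the scatter). Losing the methoxy group does not bring the number back to the level of the halogen members, since the same exchange measured against them gives a 2.7-fold higher number from compound 2 to compound 4 (0.43 log units; beyond the scatter) and a 16-fold higher number from compound 1 to compound 4 (1.20 log units; beyond the scatter). No measurement at hand explains this placing of compound 4.

The compounds shown leave open where a plain phenyl or a pyridin-2-yl group would rank, and so how much of the order belongs to the ring and how much to its substituent. Going by these compounds, the effect of a fluoro or chloro group on the thiophene ring also remains open.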